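Removing the Side Chain from Compound 3

The source may report more compounds than this note shows. Statements on the series, on what has been measured and on what is new or still open speak of the compounds shown alone.

In a functional assay on RKO cells (Homo sapiens) for inhibition, read by MTT assay, with a stated time of 48 h (on this read-out lower numbers stand for stronger inhibition and higher numbers for weaker inhibition), compound 1 (`COc1ccc(N(C)c2nc(C)nc3ccccc23)cc1OCCCCCC[Se]C#N`) gives 1540 nM, compound 2 (`COc1ccc(N(C)c2nc(C)nc3ccccc23)cc1C(=O)NCC[Se]C#N`) gives 1170 nM and compound 3 (`COc1ccc(N(C)c2nc(C)nc3ccccc23)cc1OCCCC[Se]C#N`) gives 1360 nM, which places compound 3 within the scatter of both others. Compound 4 (`COc1ccc(N(C)c2nc(C)nc3ccccc23)cc1[Se]C#N`) keeps the shared core but carries a much shorter side group: a group of 3 heavy atoms (1 carbon, 1 nitrogen, 1 selenium; no ring) in place of a group of 8 heavy atoms (5 carbon, 1 nitrogen, 1 oxygen, 1 selenium; no ring), on an aromatic carbon. Within the data shown here, three measured steps bear on this change: a 1.1-fold lower number from compound 1 to compound 3 (0.05 log units; within the scatter), a 1.3-fold lower number from compound 1 to compound 2 (0.12 log units; within the scatter) and a 1.2-fold higher number from compound 2 to compound 3 (0.07 log units; within the scatter). All three altered the side group and stayed within the scatter, but this new change is larger than any of them, so they guide it only loosely. The expected result is a 1.4-fold lower number from compound 3 to compound 4 (0.13 log units; within the scatter), with no shift beyond the scatter anticipated. For compound 4 the estimated value in this assay is 1000 nM, with an expected range of 250 nM to 2800 nM.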

Compound 4, half-maximal inhibitory concentration: 47 nM
Compound 4: middle estimate off by 21-fold (1.33 log units), on the high side; measured number outside the range, below it.
By their numbers in this assay, from the lowest: compound 4; then compounds 2, 3 and 1 (each within the scatter of the next).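

In this assay the step of a 29-fold lower number from compound 3 to compound 4 (1.46 log units; beyond the scatter) shows that attaching the group of 3 heavy atoms directly to the aromatic carbon matters far more than any earlier side-group change, and the steps of a 25-fold lower number from compound 2 to compound 4 (1.40 log units; beyond the scatter) and a 33-fold lower number from compound 1 to compound 4 (1.52 log units; beyond the scatter) agree. Compounds 1, 2 and 3 stay within the scatter of one another despite their different links, so only removing the link altogether separates compound 4 from them. No measurement here explains this result.

Still open, on these data alone, is whether a chain of one or two carbons between the ring and the selenium would keep the low number. Also open, as far as these compounds go, is whether sulfur could replace the selenium.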